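Benzylthio-triazole series: nitro replacing methyl on the phenyl ring

The compounds below may be only part of what the source reports. "The series", "measured", "known", "first", "only" and "open" are said of these compounds alone.

Measured so far in a functional assay on HeLa cells (Homo sapiens) for antiproliferative activity, read by CCK-8 assay, with a stated time of 48 h; a lower number here means a stronger inhibitor, a higher number a weaker inhibitor:
compound 1 `O=c1c2ccccc2[se]n1-c1nc(SCc2ccccc2)n[nH]1` gives > 50000 nM; this is a limit of this assay, not a number.
compound 2 `Cc1ccccc1CSc1n[nH]c(-n2[se]c3ccccc3c2=O)n1` gives 6130 nM.
compound 3 `Cc1ccc(CSc2n[nH]c(-n3[se]c4ccccc4c3=O)n2)cc1` gives 34800 nM.

Compound 3 stands highest of the two numbers; the nearest is compound 2, with a 5.7-fold higher number from compound 2 to compound 3 (0.75 log units; beyond the scatter). Compound 4 `O=c1c2ccccc2[se]n1-c1nc(SCc2ccc([N+](=O)[O-])cc2)n[nH]1` differs from compound 3 by nitro in place of methyl on an aromatic carbon. Going by the values given here, no measured step swaps a nitro for a methyl; the only steps touching this ring are an at least 8.1-fold lower number from compound 1 to compound 2 (0.91 log units; beyond the scatter) and an at least 1.4-fold lower number from compound 1 to compound 3 (0.15 log units; that floor lies within the scatter), where the second stays within the scatter, and the positional step a 5.7-fold higher number from compound 2 to compound 3 (0.75 log units; beyond the scatter). Among the compounds with values here, no step therefore bears directly on this change, and no shift beyond the scatter is expected in this assay. Compound 4 is estimated at 30000 nM, within 8000 nM to 100000 nM, meaning an expected 1.2-fold lower number from compound 3 to compound 4 (0.06 log units; within the scatter).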

Compound 4, half-maximal inhibitory concentration: 3940 nM
For compound 4 the middle estimate is 7.6-fold (0.88 log units) above the measured one; the measured number lies below the stated range.
By their numbers in this assay, from the lowest: compounds 4 and 2 (each within the scatter of the next); then compound 3. At a limit, above all of these: compound 1.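

In this assay, the outcome on this aromatic carbon para to a large group depends on which group sits there: with nitro in place of methyl, the series shows an 8.8-fold lower number from compound 3 to compound 4 (0.95 log units; beyond the scatter), so the weak result of compound 3 does not hold for this position as such. Nitro in place of hydrogen gives an at least 12-fold lower number from compound 1 to compound 4 (1.10 log units; beyond the scatter). The value of compound 1 is a limit of the assay, not a number, so this step gives only a floor: the limit of > 50000 nM in this assay, at which 1 of the 4 values shown sits.

From the compounds shown here alone, whether other groups at this place, such as a nitrile, an amine or a carboxylic acid, behave like nitro or like methyl stays open. So does the effect of nitro elsewhere on the phenyl ring.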